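This account rests on a few compounds, and the source may have more. Where it says the series, first, only, none or still open, it means among the compounds named here.

Compound 1 `C=CCc1cc(C(C)=O)c(O)cc1OCCCC#N` gives 47% in an assay on isolated protein for inhibition of leukotriene B4 receptor 1 (Homo sapiens), tested at 10 uM; on this read-out lower numbers stand for less inhibition and higher numbers for more inhibition at the one concentration tested (going by the name of the read-out); compound 2 `C=CCc1cc(C(C)=O)c(O)cc1OCCCCCC#N` gives 81% in this assay. Going by the values given here, the one measured step, a number 34 percentage points higher from compound 1 to compound 2 (beyond the scatter), is large and well beyond the scatter. Among the compounds with values here, compound 2 therefore stands highest of the two numbers, with compound 1 the only neighbour and that one far lower.

Compound 3 `C=CCc1cc(C(C)=O)c(O)cc1OCCCCCCC#N` continues along the same line: the change is cyanomethyl in place of cyano on a saturated chain carbon, five bonds along the chain from an oxygen on an aromatic ring. Within the data shown here, the only step that bears on it is the one from compound 1 to compound 2, which lengthened the same chain by the same amount and raised inhibition strongly. A further rise is expected, though compound 2 already sits near the top of the scale, so the step of a number 6 percentage points higher from compound 2 to compound 3 (within the scatter) is expected to be smaller than the one before it. Compound 3 is estimated at 87%, with a range from 68% to 98%.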

Compound 3, a percentage reported as inhibition, at one concentration (the size of the read-out at that concentration, not a potency): 97%
Compound 3: middle estimate off by 10 percentage points, on the low side, within the range that was stated.
By their numbers in this assay, from the lowest: compound 1; then compound 2; then compound 3.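

At this position, lengthening the chain still adds inhibition from an already high level: in this assay, cyanomethyl in place of cyano gives a number 16 percentage points higher from compound 2 to compound 3 (beyond the scatter) and so extends the rise seen with the earlier pair. Over the whole stretch, 3-cyanopropyl in place of cyano gives a number 50 percentage points higher from compound 1 to compound 3 (beyond the scatter) and none of the three compounds goes against the order of rising inhibition with chain length. Nothing on hand accounts for this rise.

As far as these compounds go, whether a longer chain would hold this level or lose it stays open, and with compound 3 close to the top of the scale, a single-concentration read-out can say little about further gains. Also open, from the compounds shown here alone, is how a carboxylic acid or an amide in place of the nitrile at the chain end would compare.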